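The source may hold more compounds than are shown below. What is called first, only, known or untested is meant among the compounds shown, and "the series" means these compounds.

Measured compounds:
- compound 1 `COc1ccc(-c2nn(-c3ccccc3)cc2/C=C/C(=O)c2ccc(OCc3ccccc3)c3c2OC(C)(C)C3)cc1`: 7900 nM
- compound 2 `CC1(C)Cc2c(ccc(C(=O)/C=C/c3ccccc3)c2OCc2ccccc2)O1`: > 100000 nM (a limit)
- compound 3 `Cc1ccc(-c2nn(-c3ccccc3)cc2/C=C/C(=O)c2ccc(OCc3ccccc3)c3c2OC(C)(C)C3)cc1`: > 100000 nM (a limit)

In a functional assay on PC-3 cells (Homo sapiens) for antiproliferative activity, read by MTT assay, with a stated time of 48 h (a higher number here means a weaker inhibitor, a lower number a stronger inhibitor), compound 1 gives 7900 nM. Compound 2 reaches only the limit of the measurement, > 100000 nM, so no number is known for it. Compound 3 likewise sits at a limit, > 100000 nM. Among the compounds with values here, the single step between measured compounds, an at least 12-fold higher number from compound 1 to compound 3 (1.10 log units; beyond the scatter), runs up to the limit of > 100000 nM in this assay, at which 2 of the 3 values shown sit, so its true size is not known either.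

Compound 2 therefore stands at the weak end of what has been measured, with no number of its own. Compound 4 `CC1(C)Cc2c(ccc(C(=O)/C=C/c3ccc(Cl)cc3)c2OCc2ccccc2)O1` differs from it by chloro in place of hydrogen on an aromatic carbon. Within the data shown here, no measured step covers a chloro for hydrogen exchange; the one step at hand, an at least 12-fold higher number from compound 1 to compound 3 (1.10 log units; beyond the scatter), concerns methyl against methoxy on a different compound and does not carry over. With nothing to point to a gain, the expected step of an at least 1.1-fold lower number from compound 2 to compound 4 (0.04 log units; that floor lies within the scatter) is none beyond the scatter, and compound 4 is expected most likely to remain at the limit as well. The estimate for compound 4 is 90000 nM, in the range 25000 nM to 300000 nM.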

Compound 4, half-maximal inhibitory concentration: > 100000 nM
Compound 4: no number, only a limit; the forecaster's own chance of this, stated with the estimate: 60%; middle value at least 1.1-fold (0.04 log units) away from the limit.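

Within the data shown here, compound 4 stands at a limit in this assay, with > 100000 nM as its only reading. Compound 2 is also at a limit, so no step from compound 2 to compound 4 can be read, and the reason lies in this: the limit of > 100000 nM in this assay, at which 3 of the 4 values shown sit. The compounds shown leave open whether phenyl to 4-chlorophenyl changes antiproliferative activity at all.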